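The source may report more compounds than this note shows. Statements on the series, on what has been measured and on what is new or still open speak of the compounds shown alone.

Compound 1 `CS(=O)(=O)Nc1ccc(-c2nc3ccccc3o2)cc1` carries a methyl on the sulfonyl sulfur of a shared core. In an assay on cells for inhibition of HSP60/HSP10 (Homo sapiens), with a stated time of 60 min (a higher number here means a weaker inhibitor, a lower number a stronger inhibitor), compound 1 gives only a limit of the assay, > 100000 nM. Compound 2 `O=S(=O)(Nc1ccc(-c2nc3ccccc3o2)cc1)c1ccccc1F` likewise reaches only a limit in this assay, > 100000 nM. Compound 3 `COc1ccc(Cl)cc1S(=O)(=O)Nc1ccc(-c2nc3ccccc3o2)cc1`, the compound from which the present step sets out, also stands at a limit in this assay, > 100000 nM. Because every value shown sits at the limit of > 100000 nM in this assay, at which 3 of the 3 values shown sit, the step that the two limits leave unreadable from compound 1 to compound 2 cannot be sized, and the same holds for a step that the two limits leave unreadable from compound 1 to compound 3 and for a step that the two limits leave unreadable from compound 2 to compound 3. Compound 3 therefore stands nowhere in particular among the three: all of them are equally unresolved at the limit.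

Compound 4 `O=S(=O)(Nc1ccc(-c2nc3ccccc3o2)cc1)c1ccc(Cl)cc1` differs from compound 3 in one place: 4-chlorophenyl in place of 5-chloro-2-methoxyphenyl on a sulfonyl sulfur. For the measured compounds named here, none of the measured steps is readable, so no measured step bears on this change with a size; the only guidance is that every aryl sulfonamide so far, compounds 2 and 3, remains at the limit. The step that the limit leaves unreadable from compound 3 to compound 4 is therefore expected to be none beyond the scatter, and compound 4 is most likely to sit at the limit again. For compound 4 in this assay the estimate is 200000 nM, with a range from 50000 nM to 1000000 nM.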

Compound 4, half-maximal inhibitory concentration: 61000 nM
For compound 4 the middle estimate is 3.3-fold (0.52 log units) above the measured one; the measured number falls inside the stated range.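

In this assay, for the compounds shown here, compound 4 gives 61000 nM, the only value of the four that is a number rather than a limit, so a substituent on the sulfonyl sulfur can give this series a readable value. The change to 4-chlorophenyl is recorded as an at least 1.6-fold lower number from compound 3 to compound 4 (0.21 log units; that floor lies within the scatter), as an at least 1.6-fold lower number from compound 2 to compound 4 (0.21 log units; that floor lies within the scatter) and as an at least 1.6-fold lower number from compound 1 to compound 4 (0.21 log units; that floor lies within the scatter); each of these is only a floor, so the true steps may be larger, but none is shown to lie beyond the scatter. The steps among the other three compounds still cannot be read, and those compounds give no size to set against compound 4: the limit of > 100000 nM in this assay, at which 3 of the 4 values shown sit.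

The compounds shown do not separate the two differences between 5-chloro-2-methoxyphenyl and 4-chlorophenyl, the loss of the methoxy group and the different place of the chlorine, so neither can be credited with the readable value of compound 4. Going by these compounds, it also remains open whether the chlorine itself matters, and how an unsubstituted phenyl, or a 4-trifluoromethylphenyl, a 4-aminophenyl or a 4-carboxyphenyl on the sulfonyl sulfur would compare with compound 4.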